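The source may hold more compounds than are shown below. What is called first, only, known or untested is meant among the compounds shown, and "the series" means these compounds.

Measured so far in a functional assay on HCT-116 cells (Homo sapiens) for antiproliferative activity, with a stated time of 72 h; on this read-out lower numbers stand for stronger inhibition and higher numbers for weaker inhibition:
Compound 1 `Cc1[nH]c2ccccc2c1C1=CCN(Cc2ccc(OCC(=O)NO)cc2)CC1`: 301 nM
Compound 2 `O=C(COc1ccc(CN2CC=C(c3c[nH]c4ccc(F)cc34)CC2)c(F)c1)NO`: > 5000 nM (a limit of the assay, not a number)

Compound 2 has only a limit in this assay, so no exact value is available for it. Compound 3 `Cc1[nH]c2ccccc2c1C1=CCN(Cc2ccc(OCC(=O)NO)cc2F)CC1` has not yet been measured. It differs from compound 2 in one place: 2-methyl-1H-indol-3-yl in place of 5-fluoro-1H-indol-3-yl on a double-bonded ring carbon. Here, 2-methyl-1H-indol-3-yl stands in place of 5-fluoro-1H-indol-3-yl on a double-bonded ring carbon.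

Among the measured compounds shown here, no measured pair shows this change alone, so the size of the step remains a judgement. The entering group also occurs in compound 1, which gives 301 nM in this assay. On that basis, a large move towards stronger inhibition is expected. The expected change is an at least 12-fold lower number from compound 2 to compound 3 (1.09 log units; beyond the scatter). The estimate for compound 3 is 400 nM, with an expected range from 120 nM to 1500 nM.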

Compound 3, half-maximal inhibitory concentration: 1220 nM
Estimate against measurement, compound 3: 3.1-fold (0.48 log units) below, within the range that was stated.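

In this assay, 2-methyl-1H-indol-3-yl in place of 5-fluoro-1H-indol-3-yl on the double-bonded ring carbon gives an at least 4.0-fold lower number from compound 2 to compound 3 (0.61 log units; beyond the scatter), so this position clearly affects the read-out even with the aromatic fluoro present. Compound 2 has only a limit, so that step gives a minimum size and not an exact one: the limit of > 5000 nM in this assay, at which 1 of the 3 values shown sits. The second step isolates the aromatic fluoro, with fluoro in place of hydrogen on an aromatic carbon giving a 4.1-fold higher number from compound 1 to compound 3 (0.61 log units; beyond the scatter), so this single change also weakens inhibition when 2-methyl-1H-indol-3-yl is present.

The compounds shown leave open how a chloro or methoxy group would compare with that fluoro on the aromatic carbon. They also leave open how plain 1H-indol-3-yl, carrying neither methyl nor fluoro, would behave on the double-bonded ring carbon.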